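Working notes: heptyl to 4-bromophenyl step toward compound 4

The source may hold more compounds than are shown below. What is called first, only, known or untested is meant among the compounds shown, and "the series" means these compounds.

Measured so far in a functional assay on A549 cells (Homo sapiens) for inhibition, read by MTT assay; on this read-out higher numbers stand for weaker inhibition and lower numbers for stronger inhibition:
compound 1 `CC(C)(C)OC(=O)N1CCN(CC(=O)Nc2ccc(C(=O)/C=C/c3cn(Cc4ccc(Br)cc4)nn3)cc2)CC1` gives 38400 nM
compound 2 `CCCCCCCCn1cc(/C=C/C(=O)c2ccc(NC(=O)CBr)cc2)nn1` gives 11600 nM
compound 3 `CCCCCCCCn1cc(/C=C/C(=O)c2ccc(NC(=O)CN3CCN(c4ccccc4)CC3)cc2)nn1` gives 52400 nM

Compound 3 holds the highest number of the three in this assay, and its closest neighbour is compound 1, whose number lies within the scatter of it; compound 2 sits furthest away, beyond the scatter. Going by the values given here, the one step recorded within the set, a 4.5-fold higher number from compound 2 to compound 3 (0.65 log units; beyond the scatter), concerns 4-phenylpiperazin-1-yl in place of bromo on a saturated chain carbon bound to a carbonyl carbon, a different place from the change now at hand.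

Compound 4 `O=C(CN1CCN(c2ccccc2)CC1)Nc1ccc(C(=O)/C=C/c2cn(Cc3ccc(Br)cc3)nn2)cc1` arises from compound 3 by 4-bromophenyl in place of heptyl on a saturated chain carbon bound to an aromatic nitrogen. Among the compounds with values here, no measured step in this assay touches that place. Compound 1 carries 4-bromobenzyl and compound 3 carries octyl, yet they also differ elsewhere, and their numbers lie within the scatter of each other, so nothing points to a shift beyond the scatter. Compound 4 is therefore expected near compound 3, with a 1.2-fold lower number from compound 3 to compound 4 (0.07 log units; within the scatter) as the estimated step, giving an estimate of 45000 nM, between 15000 nM and 130000 nM.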

Compound 4, half-maximal inhibitory concentration: 42100 nM
Beside the measured number, compound 4's estimate is 1.1-fold (0.03 log units) above it; the range from low to high includes it.
By their numbers in this assay, from the lowest: compound 2; then compounds 1, 4 and 3 (each within the scatter of the next).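

In this assay the exchange of heptyl for 4-bromophenyl on a saturated chain carbon bound to an aromatic nitrogen now has a direct reading (a 1.2-fold lower number from compound 3 to compound 4 (0.10 log units; within the scatter)), so octyl and 4-bromobenzyl cannot be told apart at this position when the 4-phenylpiperazin-1-yl group is present. Going by these compounds alone, the second new step (a 1.1-fold higher number from compound 1 to compound 4 (0.04 log units; within the scatter)) gives the first isolated reading of phenyl in place of tert-butoxycarbonyl on an amine nitrogen in a ring, and this change also stays within the scatter. No supporting data bear on either result.

The compounds shown leave open whether a shorter chain such as butyl, or an unsubstituted benzyl, at this place would move the number beyond the scatter. They also leave open whether octyl and 4-bromobenzyl would still read alike with bromo in place of the 4-phenylpiperazin-1-yl group.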